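Indanyl to dihydrobenzofuranyl swap on the amide nitrogen

A few compounds are considered here, and "the series" means these few. Any claim that something is new, unique, unknown or untested is made for them only; others in the source may bear on it.

Two compounds of this series have numbers in an assay on HEK293T cells for antagonist activity at transient receptor potential cation channel subfamily M member 8 (Homo sapiens), read by fluorescence and calcium flux, with a stated time of 60 min; a lower number here means a stronger inhibitor, a higher number a weaker inhibitor. Compound 1, `C[C@H](c1cc(F)c(F)c(F)c1)N(C(=O)c1ccccc1)[C@@H](C(N)=O)c1ccccc1`, gives 1700 nM. Compound 2, `NC(=O)[C@@H](c1ccccc1)N(C(=O)c1ccccc1)[C@@H]1CCc2ccccc21`, gives 270 nM, the lower of the two numbers, and its gap to compound 1 lies beyond the scatter. Compound 3, `NC(=O)[C@@H](c1ccccc1)N(C(=O)c1ccccc1)[C@@H]1COc2ccccc21`, has not been measured. It differs from compound 2 by a group of 9 heavy atoms (8 carbon, 1 oxygen; one five-membered non-aromatic ring with 1 hetero atom, one six-membered aromatic ring of carbon only) in place of a group of 9 heavy atoms (9 carbon; one five-membered non-aromatic ring of carbon only, one six-membered aromatic ring of carbon only), on an amide-type nitrogen. Going by the values given here, no step between two measured compounds covers a change of this kind, so nothing measured here shows how this exchange plays out. The step from the measured compound to the new one is expected at a 1.5-fold higher number from compound 2 to compound 3 (0.17 log units; within the scatter), small, within or close to the scatter, leaning if anything toward a higher number. Because compound 2 gives 270 nM, compound 3 is estimated at 400 nM, with a range from 150 nM to 1200 nM.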

Compound 3, half-maximal inhibitory concentration: 3300 nM
Compound 3: middle estimate off by 8.3-fold (0.92 log units), on the low side, and the stated range ends below it.
By their numbers in this assay, from the lowest: compound 2; then compounds 1 and 3 (each within the scatter of the next).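

In this assay, going by these compounds alone, the entry of the oxygen-containing group in place of 2,3-dihydro-1H-inden-1-yl on the amide-type nitrogen gives a 12-fold higher number from compound 2 to compound 3 (1.09 log units; beyond the scatter) and is the first measured step at this position. Both groups have 9 heavy atoms and the same ring sizes, so this position does not accept every group of that size and ring make-up equally. The two differ by one ring carbon exchanged for oxygen, with 0 hydrogen-bond acceptors in the leaving group and 1 hydrogen-bond acceptor in the entering one, and that single exchange is enough for a large step. Nothing measured on these compounds explains the step.

As far as these compounds go, it remains open whether a sulfur or an amine nitrogen in that ring place would behave like the oxygen. Also open, from the compounds shown here alone, is how the opposite configuration at the ring stereocentre would read, and whether the step holds with a fluorine on the benzoyl ring.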